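The source may hold more compounds than are shown below. What is called first, only, known or untested is meant among the compounds shown, and "the series" means these compounds.

In a functional assay on Maver1 cells (Homo sapiens) for inhibition, read by luminescence and CellTiter-Glo, with a stated time of 72 h (a lower number here means a stronger inhibitor, a higher number a weaker inhibitor), compound 1, whose structure is `CCOC(=O)c1cc(-c2ccc(Oc3ccccc3)cc2)nn1Cc1cccc(NC(=O)CCl)c1`, gives 500 nM. Among the compounds with values here, compound 2, with the structure `C/C=C/C(=O)Nc1cccc(Cn2nc(-c3ccc(Oc4ccccc4)cc3)cc2CO)c1`, gives 8100 nM in this assay, which is the higher of the two numbers measured so far; its nearest neighbour is compound 1, and the gap between them lies beyond the usual scatter. Compound 3, drawn as `C/C=C/C(=O)Nc1cccc(Cn2nc(-c3ccc(Oc4ccccc4)cc3)cc2C(=O)OCC)c1`, is not yet measured. It differs from compound 2 in a single place: ethoxycarbonyl in place of hydroxymethyl on an aromatic carbon. The same ethoxycarbonyl group is present in compound 1, which reaches 500 nM in this assay, though compound 1 also carries a different amide on its other arm, so the two measured numbers do not isolate this one change. The step from compound 2 to compound 3 is expected to lower the number, by about a 3.2-fold lower number from compound 2 to compound 3 (0.51 log units; beyond the scatter). Compound 3 is therefore estimated at 2500 nM in this assay, within a range of 800 nM to 8000 nM.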

Compound 3, half-maximal inhibitory concentration: 14200 nM
For compound 3 the middle estimate is 5.7-fold (0.75 log units) below the measured one, and the stated range ends below it.
By their numbers in this assay, from the lowest: compound 1; then compounds 2 and 3 (each within the scatter of the next).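

In this assay the swap of hydroxymethyl for ethoxycarbonyl on this aromatic carbon gives a 1.8-fold higher number from compound 2 to compound 3 (0.24 log units; within the scatter) and so makes no real difference here, although the new group is larger and has no hydrogen-bond donor. The large difference sits instead on the other arm: with ethoxycarbonyl unchanged, prop-1-en-1-yl in place of chloromethyl on a carbonyl carbon gives a 28-fold higher number from compound 1 to compound 3 (1.45 log units; beyond the scatter). Nothing at hand explains why either change behaves as it does.

The compounds shown leave open how a carboxylic acid or an amine on this aromatic carbon would read. They also leave open whether a longer chain on the carbonyl carbon would stay close to compound 3 or approach compound 1.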